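Halogen pattern on the aryl amine: towards compound 3

The compounds below may be only part of what the source reports. "The series", "measured", "known", "first", "only" and "open" are said of these compounds alone.

Within the data shown here, the two measured members share one core and differ only on the aryl amine. Compound 1 `CN1CCN(CCCOc2cccc3nc(Nc4ccc(Cl)c(F)c4)ccc23)CC1` carries a chloro group where compound 2 `CN1CCN(CCCOc2cccc3nc(Nc4ccc(F)c(F)c4)ccc23)CC1` carries fluoro. In a functional assay on U-251 cells (Homo sapiens) for inhibition, read by sulforhodamine B assay, with a stated time of 48 h (a higher number here means a weaker inhibitor of growth, a lower number a stronger inhibitor of growth), compound 1 gives 1810 nM, and compound 2 gives 2680 nM. Among the two numbers shown compound 2 does not separate from compound 1, since a 1.5-fold higher number from compound 1 to compound 2 (0.17 log units; within the scatter). Compound 3 `CN1CCN(CCCOc2cccc3nc(Nc4cc(Cl)cc(Cl)c4)ccc23)CC1` is not yet measured; it carries 3,5-dichlorophenyl in place of 3,4-difluorophenyl on a nitrogen on an aromatic ring. Among the measured compounds shown here, only one measured step bears on this change: a 1.5-fold higher number from compound 1 to compound 2 (0.17 log units; within the scatter), which shows that fluoro in place of chloro on an aromatic carbon moved the number little. For the measured compounds named here, no measured step speaks to the rest of the change from 3,4-difluorophenyl to 3,5-dichlorophenyl, so that part of the change is unanchored. The expected step in this assay is therefore a 1.3-fold lower number from compound 2 to compound 3 (0.13 log units; within the scatter), nothing beyond the scatter. Compound 3 is estimated at 2000 nM, with a range from 700 nM to 6000 nM.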

Compound 3, concentration for 50% growth inhibition: 1720 nM
For compound 3 the middle estimate is 1.2-fold (0.07 log units) above the measured one; the measured number falls inside the stated range.
By their numbers in this assay, from the lowest: compounds 3, 1 and 2 (each within the scatter of the next).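

In this assay, the aryl group on the amine nitrogen now changes in both halogen and substitution pattern, not in one halogen alone (a 1.6-fold lower number from compound 2 to compound 3 (0.19 log units; within the scatter)) (and a 1.1-fold lower number from compound 1 to compound 3 (0.02 log units; within the scatter)). Both steps lie within the scatter, so 3,5-dichlorophenyl does not separate from 3,4-difluorophenyl or from 4-chloro-3-fluorophenyl, and at this position the three halogenated aryl groups cannot be told apart. No supporting data bear on why these numbers stay together.

From the compounds shown here alone, all three aryl groups carry halogens alone, so it stays open whether a methoxy group, a nitrile or an unsubstituted phenyl on the same nitrogen would leave the number unchanged. Going by these compounds, the rest of the shared core is constant across these compounds, so the effect of a longer chain on the ring oxygen also remains open.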